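Adding two methyl groups to the most active compound

The compounds below may be only part of what the source reports. "The series", "measured", "known", "first", "only" and "open" are said of these compounds alone.

In a functional assay on HL-60 cells (Homo sapiens) for inhibition (on this read-out lower numbers stand for stronger inhibition and higher numbers for weaker inhibition), compound 1 (`O=C1Nc2ccccc2/C1=C1/Nc2ccccc2/C1=N\OCC(O)CSc1nnc(Nc2ccccc2)s1`) gives 9520 nM while compound 2 (`Cc1cccc(Nc2nnc(SCC(O)CO/N=C3C(=C4/C(=O)Nc5ccccc54)/Nc4ccccc4/3)s2)c1C`) gives 12000 nM and compound 3 (`O=C1/C(=C2/C(=O)N(CC(O)CSc3nnc(Nc4ccccc4)s3)c3ccccc32)Nc2ccccc21`) gives 1350 nM as the lowest number of the three. The gaps from compound 3 to both others lie beyond the scatter, so it is the strongest inhibitor so far.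

Compound 4 (`Cc1ccc(Nc2nnc(SCC(O)CN3C(=O)/C(=C4\Nc5ccccc5C4=O)c4ccccc43)s2)c(C)c1`) differs from compound 3 in one place: 2,4-dimethylphenyl in place of phenyl on a nitrogen on an aromatic ring.

For the measured compounds named here, only one measured step bears on this change. The step of a 1.3-fold higher number from compound 1 to compound 2 (0.10 log units; within the scatter) came with 2,3-dimethylphenyl in place of phenyl and stays within the scatter. It is an imperfect guide, since it has a different dimethylphenyl on the core of compound 1, and no such swap has been measured on the core of compound 3.

In this assay the expected change is a 1.2-fold higher number from compound 3 to compound 4 (0.07 log units; within the scatter) and no shift beyond the scatter is expected. The estimate for compound 4 is 1600 nM within an expected range of 700 nM to 3800 nM for now.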

Compound 4, half-maximal inhibitory concentration: 4280 nM
Compound 4: the middle estimate sits 2.7-fold (0.43 log units) below what was measured; the whole stated range lies below it.
By their numbers in this assay, from the lowest: compound 3; then compound 4; then compounds 1 and 2 (each within the scatter of the next).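

On the core of compound 3, the phenyl on this nitrogen does not tolerate every dimethylphenyl swap: in this assay, 2,4-dimethylphenyl gives a 3.2-fold higher number from compound 3 to compound 4 (0.50 log units; beyond the scatter), a modest loss of inhibition beyond the scatter. The earlier step, a 1.3-fold higher number from compound 1 to compound 2 (0.10 log units; within the scatter), stayed within the scatter, so adding two methyl groups here does not always leave the number unchanged. Nothing available accounts for this rise in the number.

As far as these compounds go, the two steps differ in both the core and the placing of the methyl groups, so it remains open which of these matters; 2,4-dimethylphenyl on the core of compound 1 and 2,3-dimethylphenyl on the core of compound 3 would separate them. Also open, from the compounds shown here alone, is how a phenyl carrying one methyl group, a methoxyphenyl or a pyridyl ring would behave at this position.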